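Phenethyl for 4-fluorophenyl on the shared core

This account rests on a few compounds, and the source may have more. Where it says the series, first, only, none or still open, it means among the compounds named here.

Measured so far in an ADME assay for permeability, using PAMPA, with a stated time of 30 min, at pH 7.4; on this read-out lower numbers stand for lower permeability and higher numbers for higher permeability:
- compound 1 `COc1cccc(CNCCCNc2ccnc3cc(Oc4ccc(F)cc4)ccc23)c1O`: 317 10^-6 cm/s
- compound 2 `COc1cccc(CNCCCNc2ccnc3cc(Oc4cccc(N(C)C)c4)ccc23)c1O`: 317 10^-6 cm/s
- compound 3 `COc1cccc(CNCCCNc2ccnc3cc(-c4ccc(F)cc4)ccc23)c1O`: 237 10^-6 cm/s

Compound 3 carries the smallest number of the three as read, but the gaps that separate it from the others, a 1.3-fold lower number from compound 1 to compound 3 (0.13 log units; within the scatter) and a 1.3-fold lower number from compound 2 to compound 3 (0.13 log units; within the scatter), both lie within the scatter, as does no change at the digits printed from compound 1 to compound 2 (within the scatter). The three compounds are therefore indistinguishable in this assay.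

Compound 4 `COc1cccc(CNCCCNc2ccnc3cc(CCc4ccccc4)ccc23)c1O` is the next member; compared with compound 3 the change is phenethyl in place of 4-fluorophenyl on an aromatic carbon. Each step measured so far at this position has stayed within the scatter, so no step beyond the scatter is expected here either: the estimate for compound 4 is a 1.1-fold higher number from compound 3 to compound 4 (0.02 log units; within the scatter), giving 250 10^-6 cm/s with a range from 140 10^-6 cm/s to 420 10^-6 cm/s.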

Compound 4, apparent permeability: 23 10^-6 cm/s
Beside the measured number, compound 4's estimate is 11-fold (1.04 log units) above it; measured number outside the range, below it.
By their numbers in this assay, from the lowest: compound 4; then compounds 3, 1 and 2 (each within the scatter of the next).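

In this assay this position proves sensitive to the group it carries: the replacement of 4-fluorophenyl by phenethyl gives a 10-fold lower number from compound 3 to compound 4 (1.01 log units; beyond the scatter) and lies beyond the scatter, whereas every earlier step stayed within it. The phenoxy-bearing compounds show the same, with a 14-fold lower number from compound 2 to compound 4 (1.14 log units; beyond the scatter) and a 14-fold lower number from compound 1 to compound 4 (1.14 log units; beyond the scatter) both beyond the scatter. No measurement at hand accounts for this difference.

For the compounds shown here, with phenethyl the only group of its kind here, it stays open whether a benzyl group or a longer chain such as phenylpropyl would match compound 4 or compound 3. On these data alone, whether a fluorine on the phenethyl ring would alter the number also stays open.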